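Aryl substituent change on the fused core, agonist potency

The source may hold more compounds than are shown below. What is called first, only, known or untested is meant among the compounds shown, and "the series" means these compounds.

Measured compounds:
compound 1 `CC#CC(CC(=O)O)c1ccc(OCc2ccc3nc(-c4ccc(C(C)C)cc4)cn3c2)cc1` 528 nM
compound 2 `CC#CC(CC(=O)O)c1ccc(OCc2ccn3cc(-c4ccc(F)cc4)nc3c2)cc1` 783 nM
compound 3 `CC#CC(CC(=O)O)c1ccc(OCc2ccc3nc(-c4ccc(C5CCCCC5)cc4)cn3c2)cc1` 417 nM

All three compounds were run in an assay on isolated protein for agonist activity at Free fatty acid receptor 1 (Homo sapiens); a higher number here means that more compound is needed for the effect, a lower number that less compound is needed. Compound 2 gives the highest of the three numbers, with 783 nM, but its gaps to compound 1 and to compound 3 are both within the scatter, so the three stand together.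

Compound 4 `CC#CC(CC(=O)O)c1ccc(OCc2ccn3cc(-c4cccc(C)c4)nc3c2)cc1` has not yet been measured. Its difference from compound 2 is 3-methylphenyl in place of 4-fluorophenyl on an aromatic carbon.

For the measured compounds named here, one measured step bears on it, the exchange of one group on an aromatic carbon for another with no change of donors or acceptors: a 1.3-fold lower number from compound 1 to compound 3 (0.10 log units; within the scatter). That step stayed within the scatter, and the change from compound 2 to compound 4 is of the same kind, a swap of one neutral aryl group for another of the same heavy-atom count. No step beyond the scatter in this assay is therefore expected.

Compound 4 is expected at 700 nM, within 300 nM to 1800 nM, that is a 1.1-fold lower number from compound 2 to compound 4 (0.05 log units; within the scatter).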

Compound 4, half-maximal effective concentration: 1510 nM
The estimate for compound 4 lay 2.2-fold (0.33 log units) below the measured number; the measured number falls inside the stated range.
By their numbers in this assay, from the lowest: compounds 3, 1, 2 and 4 (each within the scatter of the next, the first and the last beyond it).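

In this assay, 3-methylphenyl in place of 4-fluorophenyl gives a 1.9-fold higher number from compound 2 to compound 4 (0.29 log units; within the scatter) on an aromatic carbon of the five-membered aromatic ring, next to the ring nitrogen. For the compounds shown here, this adds a first measured aryl exchange at this position, and it stays within the scatter despite changing both the substituent and where it sits on the phenyl ring. The data give no reason for the direction of this step.

Compound 2 and compound 4 do not separate the change from fluorine to methyl from the change in its place on the phenyl ring, which 4-methylphenyl or 3-fluorophenyl at this position could address. Also open, on these data alone, is whether an amine, a carboxylic acid or a longer chain on this phenyl ring would give a step beyond the scatter.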